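The compounds below may be only part of what the source reports. "The series", "measured", "known", "first", "only" and "open" are said of these compounds alone.

Of the compounds shown here, three have been read in an assay on HEK293 cells for positive allosteric modulation of metabotropic glutamate receptor 2 (Rattus norvegicus), read by thallium flux, with a stated time of 2.5 min; on this read-out higher numbers stand for larger maximal responses and lower numbers for smaller maximal responses. Compound 1 `COc1cc(C(=O)O)ccc1OCCCCOc1ccc(C(=O)CC(C)(C)C)c(O)c1C` gives 98.6%. Compound 2 `Cc1c(OCCCCOc2ccccc2C(=O)O)ccc(C(=O)CC(C)C)c1O` gives 92.4%. Compound 3 `Cc1c(OCCCCOc2ccccc2C(=O)O)ccc(C(=O)CC2CCCC2)c1O` gives 98.8%. Compound 2 differs from compound 1 and from compound 3 by amounts that both lie within the usual scatter, so none of the three can be set apart as giving a larger or smaller maximal response; all three sit close to a full response.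

Among the measured compounds shown here, the only single-point step measured so far, a number 6.4 percentage points higher from compound 2 to compound 3 (within the scatter), concerns the saturated chain carbon bound to the carbonyl carbon and stays within the scatter.

For the measured compounds named here, compound 4 `Cc1c(OCCCCOc2ccc(C(=O)O)cc2F)ccc(C(=O)CC(C)C)c1O` has not yet been read in this assay. Relative to compound 2 the change is 4-carboxy-2-fluorophenyl in place of 2-carboxyphenyl on an oxygen on a saturated carbon. Going by the values given here, no measured step touches the carboxyphenyl end of the chain, so nothing in the data speaks to this change directly. What the data do show is that all three measured compounds, across the variation at the other end, give near-full responses.

Compound 4 is therefore expected to give about 93%. The range for compound 4 is expected to run from 80% to 103%. The implied step a number 0.6 percentage points higher from compound 2 to compound 4 (within the scatter) is expected to stay within the scatter.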

Compound 4, largest response reached (reported as percent of maximum), in percent of the reference or control that the assay uses: 85%
Estimate against measurement, compound 4: 8 percentage points above; the range from low to high includes it.
By their numbers in this assay, from the lowest: compounds 4, 2, 1 and 3 (each within the scatter of the next, the first and the last beyond it).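

In this assay, among the compounds shown here, 4-carboxy-2-fluorophenyl in place of 2-carboxyphenyl on an oxygen on a saturated carbon gives a number 7.4 percentage points lower from compound 2 to compound 4 (within the scatter) and is the first single-place step read at this end of the chain. This end can therefore take a different carboxyphenyl pattern with a fluorine added and still stay within the scatter, the same outcome so far as the step at the saturated chain carbon bound to the carbonyl carbon, a number 6.4 percentage points higher from compound 2 to compound 3 (within the scatter) and thus no sign yet that either end controls the maximal response. No measurement at hand bears on why this replacement reads as it does.

The swap moves the carboxyl group and adds fluorine in one step, so 4-carboxyphenyl without fluorine, or 2-carboxyphenyl carrying fluorine, would be needed to tell the two apart. Also open is whether the response survives when the carboxylic acid itself gives way to a tetrazole or a primary amide, since every compound shown carries the acid.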